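Removing two methoxy groups from a chalcone-type antiproliferative scaffold

A few compounds are considered here, and "the series" means these few. Any claim that something is new, unique, unknown or untested is made for them only; others in the source may bear on it.

The measured compounds so far:
compound 1, `COc1ccc(/C=C(/C(=O)c2cc(OC)c(OC)c(OC)c2)c2ccc(OC)cc2OC)cc1`, 90000 nM
compound 2, `COc1cc(C(=O)C(=Cc2ccccc2)c2ccccc2)cc(OC)c1OC`, 6300000 nM

Of the compounds shown here, two have been measured in a functional assay on K562 cells (Homo sapiens) for antiproliferative activity, read by MTT assay, with a stated time of 5 days; a higher number here means a weaker inhibitor, a lower number a stronger inhibitor. Compound 1 gives 90000 nM, and compound 2 gives 6300000 nM. Compound 1 therefore stands at the lowest number of the two, and the gap between compound 1 and compound 2 lies well beyond the usual scatter of this kind of measurement. Going by the values given here, no single-point step between the two measured compounds can be drawn, as they differ in more than one place.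

The next compound, compound 3 with the structure `COc1ccc(/C=C(/C(=O)c2cc(OC)c(OC)c(OC)c2)c2ccccc2)cc1`, follows the step from compound 1 by one change: phenyl in place of 2,4-dimethoxyphenyl on a double-bonded chain carbon bound to a carbonyl carbon and a double-bonded chain carbon. The shared core, the carbonyl and the other aromatic substituent are kept.

Because compound 2, which lacks the methoxy substitution on both of its terminal rings, gives 6300000 nM, the step from compound 1 to compound 3 is expected to move toward a higher number in this assay, beyond the scatter. Compound 3 is estimated at 500000 nM, with a range from 150000 nM to 2000000 nM, corresponding to an expected step of a 5.6-fold higher number from compound 1 to compound 3 (0.74 log units; beyond the scatter).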

Compound 3, half-maximal inhibitory concentration: 20000 nM
Compound 3: the middle estimate sits 25-fold (1.40 log units) above what was measured; measured number below the stated range.
By their numbers in this assay, from the lowest: compound 3; then compound 1; then compound 2.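

In this assay the change at this place, on a double-bonded chain carbon bound to a carbonyl carbon and a double-bonded chain carbon, gives a 4.5-fold lower number from compound 1 to compound 3 (0.65 log units; beyond the scatter), so the 2,4-dimethoxyphenyl group is not required here for a number as low as that of compound 1. The earlier pair could not show this, as compound 1 and compound 2 differ in more than one place, and it also shows that phenyl at this place does not by itself bring a high number: compound 3 gives 20000 nM, whereas compound 2, which also carries phenyl here, gives 6300000 nM. No measurement shown alongside these numbers accounts for the step.

The compounds shown leave open whether the step follows from losing one particular methoxy group or needs the loss of both, as only the ring with both and the ring with neither appear here. They also leave open how a hydroxy group or an amine on this phenyl would read in this assay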